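This account rests on a few compounds, and the source may have more. Where it says the series, first, only, none or still open, it means among the compounds named here.

Among the compounds with values here, in a functional assay on MCF7 cells (Homo sapiens) for cytotoxicity, read by MTT assay, with a stated time of 72 h (on this read-out lower numbers stand for stronger inhibition and higher numbers for weaker inhibition), compound 2 (`[O-][S+](CCCN=C=S)Cc1ccccc1`) gives 7920 nM, the higher of the two numbers measured so far, while compound 1 (`[O-][S+](CCCCN=C=S)Cc1ccccc1`) gives 3300 nM. Compound 3 (`[O-][S+](CCCCCN=C=S)Cc1ccccc1`) has not yet been measured. Set against compound 2, it carries a group of 5 heavy atoms (3 carbon, 1 nitrogen, 1 sulfur; no ring) in place of a group of 3 heavy atoms (1 carbon, 1 nitrogen, 1 sulfur; no ring), on a saturated chain carbon, three bonds along the chain from a sulfur. Within the data shown here, only one measured step bears on this change: a 2.4-fold higher number from compound 1 to compound 2 (0.38 log units; beyond the scatter). That step is modest but beyond the scatter, and it replaces a group of 4 heavy atoms with a group of 3 heavy atoms at the same place. Compound 3 departs from compound 2 in the opposite sense, so a lower number is expected, though a single step cannot show whether the trend carries on. The expected change is a 2.6-fold lower number from compound 2 to compound 3 (0.42 log units; beyond the scatter), again modest. For compound 3 the estimate is 3000 nM, with an expected range of 1200 nM to 7000 nM.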

Compound 3, half-maximal inhibitory concentration: 3830 nM
Compound 3: the middle estimate sits 1.3-fold (0.11 log units) below what was measured, within the range that was stated.
By their numbers in this assay, from the lowest: compounds 1 and 3 (each within the scatter of the next); then compound 2.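

In this assay, the longer group on the saturated chain carbon, three bonds along the chain from a sulfur, again goes with a lower number, with a 2.1-fold lower number from compound 2 to compound 3 (0.32 log units; beyond the scatter). The earlier step therefore has a second, separate counterpart, but the trend does not carry on in a steady line: with a 1.2-fold higher number from compound 1 to compound 3 (0.06 log units; within the scatter), compound 1 and compound 3 stand level within the scatter, so among these three compounds only the shortest chain, in compound 2, stands apart. No evidence is available on what lies behind this pattern.

As far as these compounds go, whether a longer chain would stay level with compound 1 and compound 3 or move away from them remains open. So does how an amine or a carboxylic acid in place of these groups would read in this cell assay.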